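A few compounds are considered here, and "the series" means these few. Any claim that something is new, unique, unknown or untested is made for them only; others in the source may bear on it.

Measured compounds:
compound 1 `O=C(N/N=C/c1ccncc1)c1cccnc1Nc1cccc(C(F)(F)F)c1` — 45.9%
compound 2 `CNc1ncccc1C(=O)N/N=C/c1ccccc1` — 14.8%
compound 3 `CNc1ncccc1C(=O)N/N=C/c1cccc(Cl)c1` — 40.4%

All three were tested in a functional assay on the whole organism (strain Wistar) for inhibition, with Rattus norvegicus as the target, read by paw edema, with a stated time of 4 h, at a dose of 10 mg/kg by the intraperitoneal route; a higher number here means more inhibition at the dose given (going by the name of the read-out), a lower number less inhibition. Among them compound 2 stands lowest of the three numbers shown; the step of a number 25.6 percentage points higher from compound 2 to compound 3 (beyond the scatter) lies beyond the scatter, and compound 1 lies further away still, its value above that of compound 2 by more than the scatter.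

Compound 4 `CNc1ncccc1C(=O)N/N=C/c1ccc(Cl)cc1` has not yet been measured. It differs from compound 2 by chloro in place of hydrogen on an aromatic carbon, on an aromatic carbon of a six-membered aromatic ring of carbon only, para to a large group. For the measured compounds named here, the one measured step that bears on this change is the step from compound 2 to compound 3, in which chloro in place of hydrogen on an aromatic carbon gave a number 25.6 percentage points higher from compound 2 to compound 3 (beyond the scatter), a modest rise. Compound 4 carries the same chloro on the same ring, so a rise of a similar order is expected, though the data give no direct guide to how closely the new place will follow the old one. The step from compound 2 to compound 4 is therefore estimated at a number 23.2 percentage points higher from compound 2 to compound 4 (beyond the scatter). Compound 4 is expected to give about 38% in this assay, within a range from 22% to 52%.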

Compound 4, a percentage reported as inhibition, in the whole organism at one dose (the size of the read-out at that dose, not a potency): 18.2%
For compound 4 the middle estimate is 19.8 percentage points above the measured one; the whole stated range lies above it.
By their numbers in this assay, from the lowest: compounds 2 and 4 (each within the scatter of the next); then compounds 3 and 1 (each within the scatter of the next).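

In this assay, chloro in place of hydrogen on an aromatic carbon, para to a large group, gives a number 3.4 percentage points higher from compound 2 to compound 4 (within the scatter), so at this place the change leaves the read-out within the usual spread of repeated measurements. The earlier step, a number 25.6 percentage points higher from compound 2 to compound 3 (beyond the scatter), therefore cannot be taken as an effect of chloro on this ring wherever it sits: compound 3 gives 40.4% and compound 4 gives 18.2%, the same added atom at two different places, and the outcome in this small set depends on the place and not on the group alone. Nothing shown here offers a measured reason for this difference between the two places.

From the compounds shown here alone, it remains open whether another group at the place para to a large group, such as an amine, a carboxylic acid or a methoxy group, would give a step beyond the scatter where chloro does not. Going by these compounds, it is also open whether the same dependence on place would appear on the core of compound 1, or at another dose or time.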